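The compounds below may be only part of what the source reports. "The series", "measured", "known", "first", "only" and "open" are said of these compounds alone.

Compound 2 `Cc1ccc(S(=O)(=O)/N=C(/CCNC2=CC(=O)c3ccccc3C2=O)Nc2cccc(C)c2)cc1` is tested in a functional assay on A549 cells (Homo sapiens) for cytotoxicity, read by MTT assay, with a stated time of 48 h (on this read-out lower numbers stand for stronger inhibition and higher numbers for weaker inhibition), where compound 2 gives 18700 nM. For the measured compounds named here, that is the higher of the two numbers measured so far; its nearest neighbour is compound 1 `Cc1ccc(S(=O)(=O)/N=C(/CCNC2=CC(=O)c3ccccc3C2=O)Nc2ccccc2[N+](=O)[O-])cc1`, which in this assay gives 5010 nM. Going by the values given here, the one step measured between them, a 3.7-fold higher number from compound 1 to compound 2 (0.57 log units; beyond the scatter), replaced 2-nitrophenyl with 3-methylphenyl on the amine nitrogen and is the only guide to how this position behaves. Compound 3 `Cc1ccc(S(=O)(=O)/N=C(/CCNC2=CC(=O)c3ccccc3C2=O)Nc2ccc(Cl)cc2Cl)cc1` differs from compound 2 by 2,4-dichlorophenyl in place of 3-methylphenyl on an amine nitrogen. Among the compounds with values here, no measured step covers 2,4-dichlorophenyl at this position, so the expectation rests only on the size of the change seen when 3-methylphenyl entered. A step of comparable size in either direction is plausible, and the estimate is centred close to compound 2: the expected step is a 1.9-fold lower number from compound 2 to compound 3 (0.27 log units; within the scatter), and compound 3 is expected to give 10000 nM, with a range from 3500 nM to 30000 nM.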

Compound 3, half-maximal inhibitory concentration: 32900 nM
Beside the measured number, compound 3's estimate is 3.3-fold (0.52 log units) below it, and the stated range ends below it.
By their numbers in this assay, from the lowest: compound 1; then compounds 2 and 3 (each within the scatter of the next).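

In this assay, putting 2,4-dichlorophenyl in place of 3-methylphenyl on the amine nitrogen gives a 1.8-fold higher number from compound 2 to compound 3 (0.25 log units; within the scatter), so these two groups cannot be told apart at this position, although one carries two chlorine atoms and the other a single methyl group. The comparison with compound 1 now rests on two steps, the new one being a 6.6-fold higher number from compound 1 to compound 3 (0.82 log units; beyond the scatter), and 2-nitrophenyl stands alone among the three groups with the lowest number, its steps to both others lying beyond the scatter.

From the compounds shown here alone, whether the lower number of compound 1 belongs to the nitro group itself or to where it sits on the ring stays open, as does the behaviour of 4-nitrophenyl, unsubstituted phenyl or benzyl on this nitrogen. Nothing available explains why 2-nitrophenyl separates from the other two groups.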